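A few compounds are considered here, and "the series" means these few. Any claim that something is new, unique, unknown or untested is made for them only; others in the source may bear on it.

Measured so far in a functional assay on the whole organism for agonist activity, with Mus musculus as the target; a lower number here means that less compound is needed, a higher number that more compound is needed for the effect:
- compound 1 `CC(=O)N(C)CC#CCn1cncc1C`: 45 mg/kg
- compound 2 `COC(=O)N(C)CC#CCn1cncc1C`: > 100 mg/kg (a limit)
- compound 3 `CCOC(=O)N(C)CC#CCn1cncc1C`: > 100 mg/kg (a limit)

Compound 3 has no number, only the limit > 100 mg/kg. The series mostly stands at the limit of > 100 mg/kg in this assay, at which 2 of the 3 values shown sit.

Compound 4 `CCOC(=O)N(C)C(C)C#CCn1cncc1C` differs from compound 3 by a single change, methyl in place of hydrogen on a saturated chain carbon bound to an amide-type nitrogen and a triple-bonded carbon.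

Among the compounds with values here, no measured step involves this place. The two readable steps both concern the carbonyl substituent: an at least 2.2-fold higher number from compound 1 to compound 2 (0.34 log units; beyond the scatter) with methoxy in place of methyl on a carbonyl carbon, and an at least 2.2-fold higher number from compound 1 to compound 3 (0.34 log units; beyond the scatter) with ethoxy in place of methyl on a carbonyl carbon. Within the data shown here, the only other methyl-for-hydrogen change sits elsewhere, on a saturated chain carbon bound to an oxygen next to a carbonyl group, and gives a step that the two limits leave unreadable from compound 2 to compound 3.

With no readable precedent, no step beyond the scatter is expected in this assay, and compound 4 is likely to be reported as a limit again. The expected step is a step that the limit leaves unreadable from compound 3 to compound 4. For compound 4 the estimate is 130 mg/kg, with an expected range of 60 mg/kg to 300 mg/kg.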

Compound 4, dose for half-maximal effect: > 100 mg/kg
Compound 4 ended at the assay's limit; the forecaster's own chance of this, stated with the estimate: 80%; the middle value lies beyond the limit too.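

In this assay compound 4 gives > 100 mg/kg, a limit and not a number. Compound 3 also stands at a limit, so no step can be read between compound 3 and compound 4. The compounds shown leave open what methyl in place of hydrogen at this carbon does to the dose, and the series still mostly stands at one value: the limit of > 100 mg/kg in this assay, at which 3 of the 4 values shown sit.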